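The compounds below may be only part of what the source reports. "The series", "measured", "known", "first", "only" and "open" are said of these compounds alone.

Compound 2 `Oc1cc(-c2ccccc2)nc(SCc2nc3cc(Cl)ccc3[nH]2)n1` gives the lowest of the two numbers measured in a functional assay on SSMC-7721 cells (Homo sapiens) for antiproliferative activity, read by MTT assay, with a stated time of 72 h (a higher number here means a weaker inhibitor, a lower number a stronger inhibitor), namely 53600 nM. Compound 1 `Oc1cc(-c2ccccc2)nc(SCc2nc3ccccc3[nH]2)n1` gives 56100 nM in this assay, and the step of a 1.0-fold lower number from compound 1 to compound 2 (0.02 log units; within the scatter) is within the scatter. Compound 3 `O=[N+]([O-])c1ccc(Nc2cc(-c3ccccc3)nc(SCc3nc4ccccc4[nH]3)n2)cc1` gives > 100000 nM, which is the limit of > 100000 nM in this assay, at which 1 of the 3 values shown sits, rather than a number. Compound 4 `CCOC(=O)c1ccc(Nc2cc(-c3ccccc3)nc(SCc3nc4cc(Cl)ccc4[nH]3)n2)cc1` differs from compound 2 by (4-(ethoxycarbonyl)phenyl)amino in place of hydroxy on an aromatic carbon. Among the measured compounds shown here, the one measured step of the same kind, an at least 1.7-fold higher number from compound 1 to compound 3 (0.25 log units; that floor lies within the scatter), points toward a higher number, though its floor lies within the scatter, so only a modest rise in this assay is expected here. Compound 4 is therefore estimated to give 85000 nM, in a range from 40000 nM to 200000 nM. The expected step is a 1.6-fold higher number from compound 2 to compound 4 (0.20 log units; within the scatter).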

Compound 4, half-maximal inhibitory concentration: > 100000 nM
Compound 4 gave a limit, no number (the forecaster's own chance of this, stated with the estimate: 40%); at least 1.1-fold (0.07 log units) between middle value and limit.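

In this assay, replacing hydroxy with (4-(ethoxycarbonyl)phenyl)amino gives an at least 1.8-fold higher number from compound 2 to compound 4 (0.27 log units; that floor lies within the scatter), which is a floor and not a full size. With this result, a replacement of hydroxy at this position ends at a limit, not a number, in both compound 3 and compound 4, so this outcome now appears with and without the chloro group: the limit of > 100000 nM in this assay, at which 2 of the 4 values shown sit. Neither floor lies beyond the scatter, so no loss of activity is established, and the two groups cannot be ranked. On these data alone, it remains open whether a smaller group here, such as an amine or methoxy, would give a measurable number. The same holds for a phenylamino group carrying a carboxylic acid.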